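From Bromo to Methyl in a Growth-Inhibition Series

The compounds below may be only part of what the source reports. "The series", "measured", "known", "first", "only" and "open" are said of these compounds alone.

Compounds measured in a functional assay on DU-145 cells (Homo sapiens) for inhibition, read by trypan blue exclusion, with a stated time of 96 h; a lower number here means a stronger inhibitor of growth, a higher number a weaker inhibitor of growth:
- Compound 1 `COc1ccc(/C=C(/Sc2ccc(C)cc2)C(=O)c2ccc(Br)cc2)cc1`: 50000 nM
- Compound 2 `CSc1ccc(/C=C(/Sc2ccc(C)cc2)C(=O)c2ccc(Br)cc2)cc1`: 50000 nM
- Compound 3 `O=C(/C(=C\c1ccc(Oc2ccccc2)cc1)Sc1ccc(Br)cc1)c1ccc(Br)cc1`: 50000 nM

Compound 3 stands level with compound 1 and compound 2, and the numbers do not separate the three. Compound 4 `Cc1ccc(S/C(=C/c2ccc(Oc3ccccc3)cc2)C(=O)c2ccc(Br)cc2)cc1` departs from compound 3 at one place: methyl in place of bromo on an aromatic carbon. This puts methyl in place of bromo on an aromatic carbon, turning (4-bromophenyl)sulfanyl into (4-methylphenyl)sulfanyl.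

Going by the values given here, no measured step tests this swap directly. The only one, no change at the digits printed from compound 1 to compound 2 (within the scatter), concerns a different group and stays within the scatter. Compound 1 already carries the (4-methylphenyl)sulfanyl group and gives 50000 nM, while compound 3 carries the bromo form and gives 50000 nM. On that evidence, no step beyond the scatter is expected in this assay, though the data are thin.

The expected move is a 1.1-fold lower number from compound 3 to compound 4 (0.05 log units; within the scatter).

For compound 4 the estimated value is 45000 nM, with an expected range from 15000 nM to 60000 nM.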

Compound 4, concentration for 50% growth inhibition: 1000 nM
For compound 4 the middle estimate is 45-fold (1.65 log units) above the measured one; the whole stated range lies above it.
By their numbers in this assay, from the lowest: compound 4; then compounds 1, 2 and 3 (each within the scatter of the next).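

Methyl in place of bromo on this aromatic carbon brings a 50-fold lower number from compound 3 to compound 4 (1.70 log units; beyond the scatter) in this assay, so this position, which the earlier compounds left unexplored, can move the growth-inhibition read-out strongly. The gain appears only where methyl and phenoxy occur together: phenoxy in place of methylsulfanyl gives a 50-fold lower number from compound 2 to compound 4 (1.70 log units; beyond the scatter), and phenyl in place of methyl on the oxygen gives a 50-fold lower number from compound 1 to compound 4 (1.70 log units; beyond the scatter), while compound 1 with methyl but no phenoxy and compound 3 with phenoxy but no methyl stand level. Nothing available bears on why this pairing matters.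

The compounds shown leave open whether an ethyl, a methoxy or a chloro group at this position would also keep the gain. They also leave open whether a benzyloxy group could stand in for the phenoxy.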